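The source may hold more compounds than are shown below. What is called first, only, known or untested is meant among the compounds shown, and "the series" means these compounds.

In an assay on isolated protein for inhibition of sphingomyelin phosphodiesterase (Homo sapiens), read by fluorescence, with a stated time of 30 min (on this read-out higher numbers stand for weaker inhibition and lower numbers for stronger inhibition), compound 1 `COc1ccc(C(=O)NO)cc1OCc1ccc(-c2cccnc2)cc1` gives 4970 nM, and compound 2 `COc1ccc(C(=O)NO)cc1OCc1noc(-c2ccccc2F)n1` gives 21600 nM. Compound 2 therefore stands at the higher of the two numbers in this assay , and the two values are far enough apart that the gap is real. Compound 3 `COc1ccc(C(=O)NO)cc1OCc1noc(-c2ccc(Cl)cc2)n1` differs from compound 2 by 4-chlorophenyl in place of 2-fluorophenyl on an aromatic carbon. Among the measured compounds shown here, no earlier pair of measured compounds shows what such an exchange does here, so compound 3 is expected to move little, a step of a 1.4-fold lower number from compound 2 to compound 3 (0.16 log units; within the scatter) toward a somewhat lower number at most. In this assay compound 3 is thus estimated at 15000 nM, within the range from 5000 nM to 45000 nM.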

Compound 3, half-maximal inhibitory concentration: 21600 nM
The estimate for compound 3 lay 1.4-fold (0.16 log units) below the measured number; low and high end bracket the measured number.
By their numbers in this assay, from the lowest: compound 1; then compounds 2 and 3 (each within the scatter of the next).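

In this assay, 4-chlorophenyl in place of 2-fluorophenyl on this aromatic carbon gives no change at the digits printed from compound 2 to compound 3 (within the scatter). Among the compounds shown here, this is the first step between compounds that differ in one place, and it shows that this position accepts a swap of both the halogen and its place on the phenyl ring without a readable shift in the number. No supporting data bear on this flat result. Still open, on these data alone, is whether an amine or a carboxylic acid on that phenyl ring, or a plain unsubstituted phenyl, would move the number.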